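Ethoxy to propoxy on a core at the cytotoxicity limit

This account rests on a few compounds, and the source may have more. Where it says the series, first, only, none or still open, it means among the compounds named here.

Measured compounds:
compound 1, `CCOC(=O)N1[C@@H]2C=C[C@@](OC)(C(=O)c3c2cc(OC)c(OC)c3OCC)N1C(=O)OCC`: > 300 ug/mL
compound 2, `CCOc1c(OC)c(OC)cc2c1C(=O)[C@]1(OC)C=C[C@H]2N(C(=O)OCC(C)C)N1C(=O)OCC(C)C`: > 300 ug/mL
compound 3, `COc1cc2c(c(OC)c1OC)C(=O)[C@]1(OC)C=C[C@H]2N(C(=O)OCC(C)C)N1C(=O)OCC(C)C`: > 300 ug/mL

In an ADME assay on KB cells (Homo sapiens) for cytotoxicity (a higher number here means that more compound is needed for the effect, a lower number that less compound is needed), compound 1 gives only a limit, > 300 ug/mL. Compound 2 likewise gives only a limit, > 300 ug/mL. Compound 3 too gives only a limit, > 300 ug/mL. The change methyl in place of hydrogen on a saturated chain carbon bound to an oxygen on an aromatic ring therefore yields a step that the two limits leave unreadable from compound 3 to compound 2. The difference between the core of compound 1 and that of compound 3 is not broken down here.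

Compound 4, `CCCOc1c(OC)c(OC)cc2c1C(=O)[C@]1(OC)C=C[C@H]2N(C(=O)OCC)N1C(=O)OCC`, differs from compound 1 by methyl in place of hydrogen on a saturated chain carbon, two bonds along the chain from an oxygen on an aromatic ring. This is the same kind of change as from compound 3 to compound 2, but not the same: there the place is bound to an oxygen on an aromatic ring, here it is two bonds along the chain from an oxygen on an aromatic ring. Because (the limit of > 300 ug/mL in this assay, at which 3 of the 3 values shown sit), the step that the limit leaves unreadable from compound 1 to compound 4 is expected to leave compound 4 at the same limit. Compound 4 is estimated at 400 ug/mL in this assay, between 150 ug/mL and 1500 ug/mL.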

Compound 4, concentration for half-maximal effect: > 300 ug/mL
Compound 4: no number, only a limit; the forecaster's own chance of this, stated with the estimate: 85%; the middle value does not contradict the limit.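

Within the data shown here, compound 1 and compound 4 each give only a limit in this assay, so no step between them can be read. The compounds shown leave open how much compound any of them would need for the effect.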